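Guanidine diamine series: chain modification at the amine end

A few compounds are considered here, and "the series" means these few. Any claim that something is new, unique, unknown or untested is made for them only; others in the source may bear on it.

Measured so far in an assay on isolated protein for inhibition of polyamine oxidase 1 (Zea mays), read by spectrophotometry, using a Dixon plot, at pH 6.5; on this read-out lower numbers stand for stronger inhibition and higher numbers for weaker inhibition:
compound 1, `CC(C)=CCNC(=N)NCCCCCN`, 10 nM
compound 2, `C#CCNC(=N)NCCCCN`, 250 nM
compound 3, `N=C(NCCCCCN)NCC1CC1`, 2580 nM

Compound 1 gives the lowest number of the three. Compound 2 is the nearest, and compound 3 the furthest. Within the data shown here, the one single-point step recorded, a 260-fold higher number from compound 1 to compound 3 (2.41 log units; beyond the scatter), concerns the group on the other nitrogen of the guanidine and is a large step. Among the measured compounds shown here, compound 2 differs from compound 1 at two places at once, so only the two values themselves can be compared, and no step is assigned to that pair.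

Compound 4, `CC(C)=CCNC(=N)NCCCNCCCN`, is the next compound to be measured. It differs from compound 1 in one place: (3-aminopropyl)amino in place of 2-aminoethyl on a saturated chain carbon, three bonds along the chain from an amine nitrogen. For the measured compounds named here, this change touches the amine-bearing chain, a region that none of the measured steps varies on its own; the step to compound 3 sits at a different place and offers no guide here. Going by the values given here, with no measured precedent, the working expectation is a small step in this assay, most likely a modestly higher number, as expressed by a 3.0-fold higher number from compound 1 to compound 4 (0.48 log units; beyond the scatter). Compound 4 is accordingly estimated at 30 nM, with a range from 5 nM to 250 nM, the width reflecting the lack of any comparable measured change.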

Compound 4, inhibition constant: 1210 nM
Beside the measured number, compound 4's estimate is 40-fold (1.61 log units) below it; the measured number lies above the stated range.
By their numbers in this assay, from the lowest: compound 1; then compound 2; then compound 4; then compound 3.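

In this assay, the amine-bearing chain proves to be a sensitive position: (3-aminopropyl)amino in place of 2-aminoethyl, on a saturated chain carbon, three bonds along the chain from an amine nitrogen, gives a 120-fold higher number from compound 1 to compound 4 (2.08 log units; beyond the scatter). Among these compounds, the only earlier single-place step concerned the group on the other nitrogen of the guanidine, so this is the first measured sign that a change at the amine end, with that group held constant, can also produce a large step. No available measurement accounts for the size of this step.

Compound 4 lengthens the chain and adds an amine nitrogen in the same change, so the compounds shown do not separate these two features; an all-carbon chain ending in an amine, or an ether oxygen in place of the added nitrogen, would help to tell them apart. On these data alone, it also remains open whether the same chain change would give a step of similar size with a different group on the other guanidine nitrogen, such as the cyclopropylmethyl group of compound 3.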